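The source may hold more compounds than are shown below. What is called first, only, known or untested is meant among the compounds shown, and "the series" means these compounds.

In an ADME assay on MT4 cells (Homo sapiens) for cytotoxicity, read by MTT assay, with a stated time of 4 days (on this read-out lower numbers stand for higher toxicity in this test and higher numbers for lower toxicity in this test), compound 3 `COc1ccc(-c2oc3ccc(N)cc3c(=O)c2OC)cc1` gives 200000 nM. That number lies within the usual scatter of the two other measured compounds: compound 2 `COc1c(-c2ccccc2)oc2ccc(N)cc2c1=O` gives 126000 nM, and compound 1 `COc1c(-c2ccc(C(F)(F)F)cc2)oc2ccc(NC(C)=O)cc2c1=O` gives 332000 nM. Compound 4 `COc1c(-c2ccc(C(F)(F)F)cc2)oc2ccc(N)cc2c1=O` has not yet been measured. It is compound 3 with trifluoromethyl in place of methoxy on an aromatic carbon, para to a large group: trifluoromethyl in place of methoxy on an aromatic carbon.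

Going by the values given here, only one measured step involves a change on this carbon. It is a 1.6-fold higher number from compound 2 to compound 3 (0.20 log units; within the scatter), methoxy in place of hydrogen on an aromatic carbon, and it stays within the scatter. Compound 1 carries the same trifluoromethyl as compound 4 but also differs from it elsewhere, so it offers no direct measure of this swap. No step beyond the scatter is therefore expected in this assay, and no direction can be called with confidence. The expected change is a 1.1-fold lower number from compound 3 to compound 4 (0.05 log units; within the scatter). For compound 4, the estimated value is 180000 nM, with an expected range of 90000 nM to 350000 nM.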

Compound 4, half-maximal cytotoxic concentration: 290000 nM
The estimate for compound 4 lay 1.6-fold (0.21 log units) below the measured number; the measured number falls inside the stated range.
By their numbers in this assay, from the lowest: compounds 2, 3, 4 and 1 (each within the scatter of the next, the first and the last beyond it).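

In this assay, trifluoromethyl in place of methoxy on this carbon leaves the number within the scatter: a 1.5-fold higher number from compound 3 to compound 4 (0.16 log units; within the scatter). Set against plain hydrogen on the same carbon, however, trifluoromethyl gives the first step at this position that lies beyond the scatter, though only a modest one: a 2.3-fold higher number from compound 2 to compound 4 (0.36 log units; beyond the scatter), which on this read-out means lower toxicity in this test. Hydrogen in place of acetyl on the nitrogen, with trifluoromethyl kept, also stays within the scatter: a 1.1-fold lower number from compound 1 to compound 4 (0.06 log units; within the scatter).

Nothing available explains these differences. As far as these compounds go, it remains open whether a chlorine, a nitrile or a carboxylic acid on this carbon would give a number closer to that of the hydrogen compound or to that of the trifluoromethyl compound.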